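The source may hold more compounds than are shown below. What is called first, only, known or untested is meant among the compounds shown, and "the series" means these compounds.

Going by the values given here, compound 1, `CC1(COCc2ccc(-c3ccc(F)cc3)cc2)CCn2cc([N+](=O)[O-])nc2O1`, is the starting point, and the only readings so far come from an ADME assay on MRC5 cells (Homo sapiens) for cytotoxicity, read by resazurin assay, with a stated time of 72 h; on this read-out higher numbers stand for weaker inhibition and lower numbers for stronger inhibition. In this assay compound 1 gives > 64000 nM, which is a limit of the assay and not a number. Compound 2, `O=[N+]([O-])c1cn2c(n1)OC(COCc1ccc(-c3ccc(F)cc3)cc1)CC2`, gives > 64000 nM, which is also a limit. The record so far is therefore (the limit of > 64000 nM in this assay, at which 2 of the 2 values shown sit).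

Compound 3, `CC1(COCc2ccc(OC(F)(F)F)cc2)CCn2cc([N+](=O)[O-])nc2O1`, keeps the core of compound 1 but changes one group: trifluoromethoxy in place of 4-fluorophenyl on an aromatic carbon. Here trifluoromethoxy takes the place of 4-fluorophenyl on an aromatic carbon, para to a large group.

Among the compounds with values here, only one measured step is available, a step that the two limits leave unreadable from compound 1 to compound 2. It swaps hydrogen for methyl on a saturated ring carbon, which is a different change at a different place, and it supplies no size to carry over. With no measured size to draw on, no step beyond the usual scatter is expected in this assay, and the estimated change is an at least 1.0-fold lower number from compound 1 to compound 3 (0.02 log units; that floor lies within the scatter). For compound 3 the expected half-maximal inhibitory concentration is 60000 nM, with an estimated range from 25000 nM to 64000 nM.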

Compound 3, half-maximal inhibitory concentration: > 64000 nM
Compound 3 was reported as a limit; the forecaster's own chance of this, stated with the estimate: 70%; middle value at least 1.0-fold (0.02 log units) away from the limit.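

In this assay compound 3 gives > 64000 nM, which is a limit of the assay and not a number. No size can be read for the step from compound 1 to compound 3, and the record stays at one shared ceiling: the limit of > 64000 nM in this assay, at which 3 of the 3 values shown sit.

The compounds shown leave open whether either structural change alters this read-out at all.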